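This account rests on a few compounds, and the source may have more. Where it says the series, first, only, none or still open, it means among the compounds named here.

Measured in an ADME assay on Caco-2 cells (Homo sapiens) for permeability, read by LC-MS, in the apical to basolateral direction, with a stated time of 60 min, at pH 6.5; on this read-out higher numbers stand for higher permeability and lower numbers for lower permeability:
- compound 1 `O=C(NCc1cc(Cl)ccc1-n1cnnn1)[C@@H]1[C@H]2C[C@H]2CN1C(=O)[C@H](O)c1ccccc1`: 12 10^-6 cm/s
- compound 2 `CC(C)(C)[C@@H](O)C(=O)N1NCC[C@H]1C(=O)NCc1cc(Cl)ccc1-n1cnnn1`: 7.2 10^-6 cm/s
- compound 3 `O=C(NCc1cc(Cl)ccc1-n1cnnn1)[C@@H]1[C@@H]2C[C@@H]2CN1C(=O)[C@H](O)c1ccccc1`: 2.2 10^-6 cm/s

Compound 1 stands with compound 2 at the upper end of these three numbers, the two lying within the usual scatter of each other. Going by the values given here, compound 3 is the only one clearly apart from compound 1.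

The next compound to be measured is compound 4 `CC(C)(C)OC[C@@H](O)C(=O)N1C[C@@H]2C[C@@H]2[C@H]1C(=O)NCc1cc(Cl)ccc1-n1cnnn1`, and its change from compound 1 is (tert-butoxy)methyl in place of phenyl on a saturated chain carbon bound to a carbonyl carbon and an oxygen on a saturated carbon. In words, (tert-butoxy)methyl takes the place of phenyl on a saturated chain carbon bound to a carbonyl carbon and an oxygen on a saturated carbon.

Among the compounds with values here, the one measured step, a 5.5-fold lower number from compound 1 to compound 3 (0.74 log units; beyond the scatter), gives little guidance on size, since the fact that compounds 1 and 3 differ only in the configuration as drawn and no group is exchanged there. The nearer hint comes from compound 2, which also has no phenyl and whose core differs as well. Even so, compound 2 reads 7.2 10^-6 cm/s, within the scatter of compound 1.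

On that basis, only a small fall is expected, not beyond the scatter, and the estimated change is a 1.5-fold lower number from compound 1 to compound 4 (0.18 log units; within the scatter). For compound 4 the expected value is 8 10^-6 cm/s, with an estimated range from 3 10^-6 cm/s to 20 10^-6 cm/s.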

Compound 4, apparent permeability: 17 10^-6 cm/s
Beside the measured number, compound 4's estimate is 2.1-fold (0.33 log units) below it, within the range that was stated.
By their numbers in this assay, from the lowest: compound 3; then compounds 2, 1 and 4 (each within the scatter of the next, the first and the last beyond it).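

In this assay the exchange at this position gives a 1.4-fold higher number from compound 1 to compound 4 (0.15 log units; within the scatter) and so does not separate the two groups on the core of compound 1. Going by these compounds alone, this is the first direct reading at this saturated chain carbon: phenyl, with its six-membered aromatic ring, gives way to (tert-butoxy)methyl, which has no ring and brings one hydrogen-bond acceptor at the same count of heavy atoms, and the number stays within the usual scatter, whereas the only earlier step (a 5.5-fold lower number from compound 1 to compound 3 (0.74 log units; beyond the scatter)) exchanged no group at all. Nothing measured here speaks to why this exchange leaves the number within the scatter.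

The compounds shown leave open whether this tolerance extends to other groups at this carbon, such as an amine, a carboxylic acid or a longer chain. They also leave open whether (tert-butoxy)methyl would give a similar number on the configuration drawn for compound 3, which reads 2.2 10^-6 cm/s with phenyl at this carbon.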